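This account rests on a few compounds, and the source may have more. Where it says the series, first, only, none or still open, it means among the compounds named here.

Working notes on the series in a functional assay on K562 cells (Homo sapiens) for inhibition, read by MTT assay, with a stated time of 48 h; on this read-out lower numbers stand for stronger inhibition and higher numbers for weaker inhibition.

Three compounds carry numbers. Compound 1 `CC(C)(C)C(=O)Nc1ccc(-c2cccc(C(=O)N[C@H]3CN[C@@H](C(=O)Nc4ccc(Cl)c(C(F)(F)F)c4)C3)c2)cn1` gives 28000 nM in this assay, the highest of the three numbers. Compound 2 `CC(C)(C)C(=O)Nc1ccc(-c2ccc(C(=O)N[C@H]3CN[C@@H](C(=O)Nc4ccc(Cl)c(C(F)(F)F)c4)C3)cc2)cn1` gives 11600 nM; the gap from compound 1 to compound 2 is beyond the scatter, so compound 2 reads as the stronger of the two. Compound 3 `C[C@H](NC(=O)c1ccc(-c2ccc(N)nc2)cc1)C(=O)Nc1ccc(Cl)c(C(F)(F)F)c1` gives 5950 nM, the furthest from compound 1 and again beyond the scatter. Compound 1 therefore stands at the weak end of what has been measured.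

Compound 4 `CC(=O)Nc1ccc(-c2cccc(C(=O)N[C@H]3CN[C@@H](C(=O)Nc4ccc(Cl)c(C(F)(F)F)c4)C3)c2)cn1` is not yet measured in this assay. It differs from compound 1 in one place: methyl in place of tert-butyl on a carbonyl carbon. Among the compounds with values here, no measured pair shows this change, so there is no step to lean on. With the amide linkage kept and only the acyl group shortened, the expectation for compound 4 is a step of a 1.1-fold higher number from compound 1 to compound 4 (0.06 log units; within the scatter), none beyond the scatter, leaning if anything toward a slightly higher number. Compound 4 is estimated at 32000 nM, with a range from 10000 nM to 100000 nM.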

Compound 4, half-maximal inhibitory concentration: 8710 nM
Beside the measured number, compound 4's estimate is 3.7-fold (0.57 log units) above it, and the stated range ends above it.
By their numbers in this assay, from the lowest: compounds 3, 4 and 2 (each within the scatter of the next); then compound 1.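

In this assay, within the data shown here, the acyl group on the amide nitrogen is not a silent position: methyl in place of tert-butyl on a carbonyl carbon gives a 3.2-fold lower number from compound 1 to compound 4 (0.51 log units; beyond the scatter) and is the only single-place step so far. With the amide linkage kept, the number at this position therefore responds to going from a group of 4 heavy atoms to a group of 1, although this rests on a single pair. Nothing in hand gives a reason for the shift.

Going by these compounds, only tert-butyl and methyl are covered here, so it remains open whether the number moves steadily through ethyl or isopropyl, or how an amine or a carboxylic acid on this acyl group would read. On these data alone, it also remains open whether the same change would carry over to compound 2, which holds the same (tert-butyl)carbonyl group.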